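Swapping the aryl ketone for a cyclopropyl ketone

This account rests on a few compounds, and the source may have more. Where it says the series, first, only, none or still open, it means among the compounds named here.

Of the compounds shown here, two have been measured in an assay on RBL-1 cells for inhibition of Polyunsaturated fatty acid 5-lipoxygenase (Rattus norvegicus); a lower number here means a stronger inhibitor, a higher number a weaker inhibitor. Compound 1, `O=C(/C=C\N(O)Cc1ccc(-c2ccccc2)cc1)c1ccc(F)cc1`, gives 3000 nM in this assay. Compound 2, `COC(=O)/C=C\N(O)Cc1ccc(OCc2ccccc2)cc1`, gives 4800 nM in this assay. These two numbers lie within the usual scatter of each other, so neither compound stands apart from the other on the data at hand; compound 1 simply has the smaller of the two readings.

Compound 3, `O=C(/C=C\N(O)Cc1ccc(-c2ccccc2)cc1)C1CC1`, has not yet been measured. It differs from compound 1 in one place: cyclopropyl in place of 4-fluorophenyl on a carbonyl carbon. For the measured compounds named here, no measured pair shows this kind of exchange, so there is no step in the data to lean on, and the expectation can rest only on the single value of compound 1.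

A smaller group in place of the aromatic ring is expected to leave the inhibition somewhat weaker, so the step from compound 1 to compound 3 is estimated at a 1.7-fold higher number from compound 1 to compound 3 (0.22 log units; within the scatter) in this assay, though a step no larger than the scatter is also plausible. On that basis compound 3 is expected to give about 5000 nM in this assay, most likely between 1500 nM and 20000 nM.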

Compound 3, half-maximal inhibitory concentration: 1200 nM
The estimate for compound 3 lay 4.2-fold (0.62 log units) above the measured number, outside the stated range (below it).
By their numbers in this assay, from the lowest: compound 3; then compounds 1 and 2 (each within the scatter of the next).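

The carbonyl carbon does not need the large aromatic ring for inhibition in this assay: with cyclopropyl in place of 4-fluorophenyl there is a 2.5-fold lower number from compound 1 to compound 3 (0.40 log units; beyond the scatter), a step beyond the scatter. For the compounds shown here, this is the first pair here that differs in only one place, so this change can be read directly, and it shows that a group of 3 heavy atoms can do better at this place than one of 7. The data offer no measurement that accounts for this gain.

The exchange removes the fluorine and replaces the aromatic ring in a single move, so a plain phenyl group on the same carbonyl carbon would be needed to tell those two parts apart. On these data alone, whether the trend toward a smaller group continues also stays open: a methyl or an open chain such as isopropyl would test this, and a ring one carbon larger, cyclobutyl, would show how closely the three-membered ring is tied to the result.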